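Bromo to fluoro exchange on the aryl group

The compounds below may be only part of what the source reports. "The series", "measured", "known", "first", "only" and "open" are said of these compounds alone.

Measured so far:
compound 1 `O=C1N(c2ccccc2)CCN1C1CN2CCC1CC2`: 2100 nM
compound 2 `Cc1[nH]cnc1CN1CCN(c2cccc(Br)c2)C1=O`: 10.4 nM

In a functional assay (Cavia porcellus) for antagonist activity at Serotonin 3 (5-HT3) receptor (Homo sapiens) (on this read-out lower numbers stand for stronger inhibition and higher numbers for weaker inhibition), compound 1 gives 2100 nM. In this assay compound 2 gives 10.4 nM. Compound 2 holds the lowest of the two numbers recorded; its nearest neighbour is compound 1, whose number is higher by a margin well beyond the scatter, so compound 2 is the more potent of the two by a clear distance. The two compounds share no single point of difference, so nothing can be said about which part of the change between them carries the gap.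

Compound 3 `Cc1[nH]cnc1CN1CCN(c2cccc(F)c2)C1=O` is the next entry. Relative to compound 2 the change is fluoro in place of bromo on an aromatic carbon. Among the measured compounds shown here, no pair of measured compounds records such a halogen exchange, so the size of the step is open. The working expectation is a small loss, estimated as a 3.8-fold higher number from compound 2 to compound 3 (0.59 log units; beyond the scatter), with a real chance that it stays within the scatter. Compound 3 is therefore expected to give about 40 nM, with a range from 10 nM to 160 nM.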

Compound 3, antagonist equilibrium constant: 88.3 nM
For compound 3 the middle estimate is 2.2-fold (0.34 log units) below the measured one; low and high end bracket the measured number.
By their numbers in this assay, from the lowest: compound 2; then compound 3; then compound 1.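

In this assay the halogen on the aromatic carbon, meta to a large group, gives the series its first single-place comparison, and fluoro in place of bromo yields an 8.5-fold higher number from compound 2 to compound 3 (0.93 log units; beyond the scatter). The counts of heavy atoms, hydrogen-bond donors and hydrogen-bond acceptors are the same for the two groups, and neither group adds a ring or a net charge, so this position responds to the identity of the halogen even when those counts stay unchanged, with bromo the better of the two in compound 2. No measurement on hand accounts for the size of this step.

From the compounds shown here alone, with only bromo and fluoro compared at this position, it remains open where chloro, methoxy, a nitrile or an amine would fall, and whether the order seen here would hold for the same halogens elsewhere on the aromatic ring. Going by these compounds, the gap between compound 1 and compound 2 also remains undivided among their several points of difference, so the share of the bromo group in it is unknown.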